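The source may report more compounds than this note shows. Statements on the series, on what has been measured and on what is new or still open speak of the compounds shown alone.

Measured so far:
compound 1, `c1ccc(C(c2ccccc2)[C@@H]2CC[C@H](NCc3cccs3)CO2)cc1` — 41.4 nM
compound 2, `c1ccc(C(c2ccccc2)[C@@H]2CC[C@H](NCc3ccncc3)CO2)cc1` — 28.3 nM
compound 3, `c1ccc(C(c2ccccc2)[C@@H]2CC[C@H](NCc3cccnc3)CO2)cc1` — to be measured

Within the data shown here, in an assay on striatum for inhibition of sodium-dependent dopamine transporter (Rattus norvegicus) (a lower number here means a stronger inhibitor, a higher number a weaker inhibitor), compound 2 holds the lower of the two numbers, but the only measured step, a 1.5-fold lower number from compound 1 to compound 2 (0.17 log units; within the scatter), is within the scatter, so the two aryl groups at this place are not separated. Compound 3 differs from compound 2 by pyridin-3-yl in place of pyridin-4-yl on a saturated chain carbon bound to an amine nitrogen. Among the measured compounds shown here, that earlier step is the only one bearing on this change, and since it stayed within the scatter, no step beyond the scatter is expected in this assay here either. Compound 3 is therefore estimated at 30 nM, with a range of 12 nM to 75 nM. The expected step is a 1.1-fold higher number from compound 2 to compound 3 (0.03 log units; within the scatter).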

Compound 3, inhibition constant: 145 nM
The estimate for compound 3 lay 4.8-fold (0.68 log units) below the measured number; the whole stated range lies below it.
By their numbers in this assay, from the lowest: compounds 2 and 1 (each within the scatter of the next); then compound 3.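

At the saturated chain carbon bound to an amine nitrogen, the aryl group does separate compounds in this assay: pyridin-3-yl in place of pyridin-4-yl gives a 5.1-fold higher number from compound 2 to compound 3 (0.71 log units; beyond the scatter), even though the two groups have the same atoms, joined differently. Pyridin-3-yl in place of thiophen-2-yl also goes beyond the scatter, with a 3.5-fold higher number from compound 1 to compound 3 (0.54 log units; beyond the scatter), so compound 3 stands apart from both earlier compounds. Nothing measured here accounts for this difference.

On these data alone, whether pyridin-2-yl or phenyl at this place would sit with compound 2 or with compound 3 remains open.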